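A few compounds are considered here, and "the series" means these few. Any claim that something is new, unique, unknown or untested is made for them only; others in the source may bear on it.

Compound 2 `CC(C)C[C@H](N)c1cc(C(F)(F)F)ccc1N1CCN(C(=O)CCC2CCCCC2)CC1` is measured in an assay on HEK293 cells for displacement of a labelled ligand from Melanocortin receptor 4 (Homo sapiens) (on this read-out higher numbers stand for weaker inhibition and lower numbers for stronger inhibition), where compound 2 gives 5700 nM. Of the two numbers shown it stands highest; its nearest neighbour is compound 1 `CC(C)C[C@H](N)c1cc(C(F)(F)F)ccc1N1CCN(C(=O)CNc2ccccc2)CC1`, which in this assay gives 3600 nM, and the step of a 1.6-fold higher number from compound 1 to compound 2 (0.20 log units; within the scatter) lies within the scatter. Compound 3 `CC(C)C[C@H](N)c1cc(C(F)(F)F)ccc1N1CCN(C(=O)CCC(N)=O)CC1` reaches only a limit in this assay, > 10000 nM (the limit of > 10000 nM in this assay, at which 1 of the 3 values shown sits). The step of an at least 1.7-fold higher number from compound 2 to compound 3 (0.24 log units; that floor lies within the scatter) has its floor within the scatter, whereas an at least 2.7-fold higher number from compound 1 to compound 3 (0.44 log units; beyond the scatter) lies beyond it. Compound 4 `CC(C)C[C@H](N)c1cc(C(F)(F)F)ccc1N1CCN(C(=O)COc2cccc(Cl)c2)CC1` differs from compound 2 by 3-chlorophenoxy in place of cyclohexylmethyl on a saturated chain carbon bound to a carbonyl carbon. The entering group carries an aromatic ring as does the anilino of compound 1, whose step a 1.6-fold higher number from compound 1 to compound 2 (0.20 log units; within the scatter) stayed flat, so the expected step is small: a 1.4-fold lower number from compound 2 to compound 4 (0.15 log units; within the scatter). Compound 4 is estimated in this assay at 4000 nM, between 1500 nM and 10000 nM.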

Compound 4, inhibition constant: 2600 nM
For compound 4 the middle estimate is 1.5-fold (0.19 log units) above the measured one, and the stated range covers the measured number.
By their numbers in this assay, from the lowest: compounds 4, 1 and 2 (each within the scatter of the next, the first and the last beyond it). At a limit, above all of these: compound 3.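

In this assay the step of a 2.2-fold lower number from compound 2 to compound 4 (0.34 log units; beyond the scatter) separates 3-chlorophenoxy from cyclohexylmethyl at this position, which the anilino of compound 1 did not do. Set against anilino, the step of a 1.4-fold lower number from compound 1 to compound 4 (0.14 log units; within the scatter) shows no readable change, so these two aromatic groups stand level. Carbamoylmethyl gives only a limit, so the step of an at least 3.8-fold lower number from compound 3 to compound 4 (0.58 log units; beyond the scatter) is a floor: the limit of > 10000 nM in this assay, at which 1 of the 4 values shown sits.

Open, going by these compounds, is whether the chlorine, the ether oxygen or the aromatic ring carries the difference from cyclohexylmethyl. A plain phenoxy or a cyclohexyloxy on this chain would test that.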